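The source may report more compounds than this note shows. Statements on the series, on what has been measured and on what is new or still open speak of the compounds shown alone.

Among the measured compounds shown here, in a functional assay on DU-145 cells (Homo sapiens) for inhibition, read by MTT assay, with a stated time of 48 h (on this read-out higher numbers stand for weaker inhibition and lower numbers for stronger inhibition), compound 1 `Cn1c(/C=C2\SC(=O)N(CC(=O)N3CCOCC3)C2=O)nc2ccccc21` gives 41100 nM, the only actual number available so far. The piperidin-1-yl analogue, compound 2 `Cn1c(/C=C2\SC(=O)N(CC(=O)N3CCCCC3)C2=O)nc2ccccc21`, reports > 50000 nM, which is a limit of the assay and not a number. Compound 3 `CC(C)n1c(/C=C2\SC(=O)N(CC(=O)N3CCOCC3)C2=O)nc2ccccc21` departs from compound 1 in a single place: isopropyl in place of methyl on an aromatic nitrogen. For the measured compounds named here, the one measured step, an at least 1.2-fold higher number from compound 1 to compound 2 (0.08 log units; that floor lies within the scatter), lies on a carbonyl carbon and not on this nitrogen, so it bears on the new change only weakly. Going by the values given here, no step on this nitrogen has been measured. Resting on compound 1 at 41100 nM, a change no larger than the scatter is expected in this assay, in either direction. The estimated step is a 1.1-fold lower number from compound 1 to compound 3 (0.03 log units; within the scatter). For compound 3 the expected value is 38000 nM, within an estimated range of 18000 nM to 50000 nM.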

Compound 3, half-maximal inhibitory concentration: > 50000 nM
Compound 3 ended at the assay's limit; the forecaster's own chance of this, stated with the estimate: 30%; middle value at least 1.3-fold (0.11 log units) away from the limit.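

In this assay compound 3 gives > 50000 nM, which is a limit of the assay and not a number. This gives the first step on the aromatic nitrogen, an at least 1.2-fold higher number from compound 1 to compound 3 (0.08 log units; that floor lies within the scatter), so isopropyl in place of methyl is not shown to change the read-out by more than the usual variation between repeats. The step has a floor but no upper bound, and its true size cannot be read from a value at the top of the range: the limit of > 50000 nM in this assay, at which 2 of the 3 values shown sit.

The compounds shown leave open how this nitrogen would read with hydrogen, ethyl or benzyl in place of methyl, and whether any such group would give an actual number. They also leave open whether a group such as a carboxylic acid or a primary amine on the shared core would give a clearer step.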